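A few compounds are considered here, and "the series" means these few. Any claim that something is new, unique, unknown or untested is made for them only; others in the source may bear on it.

Measured so far in a functional assay on MDA-MB-468 cells (Homo sapiens) for inhibition, read by sulforhodamine B assay, with a stated time of 48 h; on this read-out lower numbers stand for stronger inhibition of growth and higher numbers for weaker inhibition of growth:

compound 1, `O=C(Nc1cccc(-n2cc(-c3ccncc3)c(-c3ccc(Cl)c(O)c3)n2)c1)Nc1cccc(C(F)(F)F)c1`: compound 1 gives 980 nM
compound 2, `O=C(Nc1cccc(-n2cc(-c3ccncc3)c(-c3ccc(Cl)c(O)c3)n2)c1)Nc1ccc(Cl)c(Cl)c1`: compound 2 gives 729 nM
compound 3, `COc1cc(-c2nn(-c3cccc(NC(=O)Nc4ccc(Cl)c(C(F)(F)F)c4)c3)cc2-c2ccncc2)ccc1Cl`: compound 3 gives 833 nM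

Compound 3 stands second highest of the three numbers in this assay, with compound 2 nearest and compound 1 furthest, both within the scatter, so the three compounds cannot be told apart on these data.

The next compound, compound 4, `O=C(Nc1cccc(-n2cc(-c3ccncc3)c(-c3ccc(Cl)c(O)c3)n2)c1)Nc1ccc(Cl)c(C(F)(F)F)c1`, differs from compound 3 by hydrogen in place of methyl on an oxygen on an aromatic ring, that is methoxy to hydroxy, 4-chloro-3-methoxyphenyl to 4-chloro-3-hydroxyphenyl.

Within the data shown here, no measured step touches this oxygen. Among the measured compounds shown here, the one step in hand, a 1.3-fold lower number from compound 1 to compound 2 (0.13 log units; within the scatter), changes the aryl on the amide-type nitrogen and does not bear on the change here. Compounds 1 and 2 carry the hydroxy and compound 3 the methoxy, but they also differ in the urea aryl, and all three values sit within the scatter of one another. The step in this assay from compound 3 to compound 4 is therefore expected to be none beyond the scatter, a 1.0-fold lower number from compound 3 to compound 4 (0.02 log units; within the scatter).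

Compound 4 is estimated at 800 nM in this assay, with a range of 400 nM to 1600 nM.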

Compound 4, concentration for 50% growth inhibition: 541 nM
Estimate against measurement, compound 4: 1.5-fold (0.17 log units) above; the range from low to high includes it.
By their numbers in this assay, from the lowest: compounds 4, 2, 3 and 1 (each within the scatter of the next).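

In this assay, among these compounds, swapping methoxy for hydroxy on the oxygen gives the first direct reading at this position, and the change stays within the scatter (a 1.5-fold lower number from compound 3 to compound 4 (0.19 log units; within the scatter)). Among the compounds shown here, with the hydroxy held constant, compound 4 also gives the first two direct readings of substituents on the aryl of the amide-type nitrogen: trifluoromethyl in place of chloro (a 1.3-fold lower number from compound 2 to compound 4 (0.13 log units; within the scatter)) and chloro in place of hydrogen (a 1.8-fold lower number from compound 1 to compound 4 (0.26 log units; within the scatter)), both also within the scatter. No measurement here offers an explanation for these results.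

This oxygen has been read only as methoxy and hydroxy, and only with one aryl on the amide-type nitrogen. As far as these compounds go, an ethoxy group, a longer chain on the oxygen, or an amine in place of the hydroxy remains open.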